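Same Substituent Swap on a Rearranged Chalcone Core

The source may report more compounds than this note shows. Statements on the series, on what has been measured and on what is new or still open speak of the compounds shown alone.

Compound 1 `Cc1c(-n2cc(COc3ccc(/C=C/C(=O)c4cc5c(cc4O)OC(C)(C)CC5)cc3)nn2)cccc1[N+](=O)[O-]` and compound 2 `COc1ccc(-n2cc(COc3ccc(/C=C/C(=O)c4cc5c(cc4O)OC(C)(C)CC5)cc3)nn2)c([N+](=O)[O-])c1` share one core and differ only in the group on the triazole nitrogen. In a functional assay on A549 cells (Homo sapiens) for antiproliferative activity, read by MTT assay (a higher number here means a weaker inhibitor, a lower number a stronger inhibitor), compound 1 gives 65900 nM, and compound 2 gives 99500 nM. The step of a 1.5-fold higher number from compound 1 to compound 2 (0.18 log units; within the scatter) is the change (4-methoxy-2-nitrophenyl in place of 2-methyl-3-nitrophenyl on an aromatic nitrogen), and it stays within the usual scatter, so the two values do not separate.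

Compound 3 `Cc1c(-n2cc(COc3ccc(/C=C/C(=O)c4ccc5c(c4O)CCC(C)(C)O5)cc3)nn2)cccc1[N+](=O)[O-]` is built from the same atoms as compound 1, joined differently; the difference between the two cores is not broken down here. In this assay compound 3 was reported as "not active" (no number reported), and no single number was given for it.

Compound 4 `COc1ccc(-n2cc(COc3ccc(/C=C/C(=O)c4ccc5c(c4O)CCC(C)(C)O5)cc3)nn2)c([N+](=O)[O-])c1` stands to compound 3 as compound 2 stands to compound 1: the change (4-methoxy-2-nitrophenyl in place of 2-methyl-3-nitrophenyl on an aromatic nitrogen), made at the same place as before, so it is the same change. When that change was measured, it moved nothing beyond scatter, as the step from compound 1 to compound 2 showed. Applied to a starting point that already gave no activity, it is expected to leave compound 4 weak as well, and there is a real chance that this assay again reports no number. The estimate for compound 4 in this assay is 150000 nM, with a range from 50000 nM to 500000 nM, resting on the inactivity of compound 3 and the small step from compound 1 to compound 2.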

Compound 4, half-maximal inhibitory concentration: "not active" (no number reported)
Compound 4: no number reported, so the estimate cannot be set against anything.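

In this assay compound 3 and compound 4 are both reported as "not active" with no number for either, so no step can be read between them, and no further data bear on this result.

The compounds shown leave open whether 4-methoxy-2-nitrophenyl in place of 2-methyl-3-nitrophenyl makes any difference on the core of compound 3, and how far that core lies from the core of compound 1.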